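Fluoro for chloro on the 2,4-dichlorophenyl group

The source may hold more compounds than are shown below. What is called first, only, known or untested is meant among the compounds shown, and "the series" means these compounds.

In a functional assay on HT-29 cells (Homo sapiens) (on this read-out higher numbers stand for weaker inhibition of growth and lower numbers for stronger inhibition of growth), compound 1 `O=S(=O)(/C=C/c1ccc(F)cc1)Cc1ccc(Nc2ncnc3ccccc23)cc1` gives 1000 nM while compound 2 `O=S(=O)(/C=C/c1ccc(Cl)c(Cl)c1)Cc1ccc(Nc2ncnc3ccccc23)cc1` gives 11000 nM and compound 3 `O=S(=O)(/C=C/c1ccc(Cl)cc1Cl)Cc1ccc(Nc2ncnc3ccccc23)cc1` gives 24000 nM as the highest number of the three. Compound 4 `O=S(=O)(/C=C/c1ccc(F)cc1Cl)Cc1ccc(Nc2ncnc3ccccc23)cc1` differs from compound 3 by fluoro in place of chloro on an aromatic carbon on an aromatic carbon, para to a large group. Large steps bear on this: a 24-fold higher number from compound 1 to compound 3 (1.38 log units; beyond the scatter) for 2,4-dichlorophenyl in place of 4-fluorophenyl and an 11-fold higher number from compound 1 to compound 2 (1.04 log units; beyond the scatter) for 3,4-dichlorophenyl in its place. The modest 2.2-fold higher number from compound 2 to compound 3 (0.34 log units; beyond the scatter) separates the two dichlorophenyl compounds. Compound 4 keeps a chloro group that compound 1 lacks, so only part of a 24-fold higher number from compound 1 to compound 3 (1.38 log units; beyond the scatter) is expected to return. The expected move is a 4.8-fold lower number from compound 3 to compound 4 (0.68 log units; beyond the scatter) towards a lower number, beyond the scatter. The estimate for compound 4 is 5000 nM within a range of 1500 nM to 15000 nM in this assay for now.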

Compound 4, concentration for 50% growth inhibition: 100000 nM
Beside the measured number, compound 4's estimate is 20-fold (1.30 log units) below it, outside the stated range (above it).
By their numbers in this assay, from the lowest: compound 1; then compound 2; then compound 3; then compound 4.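

In this assay, fluoro in place of chloro para to a large group gives no gain in growth inhibition; the number moves the other way (a 4.2-fold higher number from compound 3 to compound 4 (0.62 log units; beyond the scatter)). Chloro in place of hydrogen on the 4-fluorophenyl group gives the largest step in the set (a 100-fold higher number from compound 1 to compound 4 (2.00 log units; beyond the scatter)), and the 2-chloro-4-fluorophenyl group also stands well apart from the 3,4-dichlorophenyl group (a 9.1-fold higher number from compound 2 to compound 4 (0.96 log units; beyond the scatter)). Nothing at hand explains this reversal.

Open, going by these compounds, is whether a methoxy, a nitrile or an amine in place of this fluoro would give a lower number, and whether the steps seen here hold with bromo in place of the remaining chloro.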